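This account rests on a few compounds, and the source may have more. Where it says the series, first, only, none or still open, it means among the compounds named here.

Of the compounds shown here, two have been measured in an ADME assay on MT4 cells (Homo sapiens) for cytotoxicity, read by MTT assay, with a stated time of 96 h; a higher number here means that more compound is tolerated, a lower number that less compound is tolerated. Compound 1 `NS(=O)(=O)c1ccc(N2N=C(c3ccc(OCc4ccccc4)cc3)CC2c2ccccc2F)cc1` gives 39000 nM in this assay, and compound 2 `Cc1ccc(C2CC(c3ccc(OCc4ccccc4)cc3)=NN2c2ccc(S(N)(=O)=O)cc2)cc1` gives 35000 nM. Within the data shown here, compound 2 holds the lowest of these two numbers, with compound 1 as its only neighbour; the single measured step, a 1.1-fold lower number from compound 1 to compound 2 (0.05 log units; within the scatter), lies within the scatter, so the two compounds cannot be told apart on this read-out. Compound 3 `Cc1cccc(C2CC(c3ccc(OCc4ccccc4)cc3)=NN2c2ccc(S(N)(=O)=O)cc2)c1` has not yet been measured. It differs from compound 2 in one place: 3-methylphenyl in place of 4-methylphenyl on a saturated ring carbon. Among the measured compounds shown here, the only measured step that bears on this change is the earlier swap at the same saturated ring carbon, a 1.1-fold lower number from compound 1 to compound 2 (0.05 log units; within the scatter), which stayed within the scatter, so no movement beyond the scatter is expected in this assay here either. The expected step is no change at the digits printed from compound 2 to compound 3 (within the scatter). Compound 3 is therefore estimated to give about 35000 nM in this assay, most likely between 15000 nM and 80000 nM.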

Compound 3, half-maximal cytotoxic concentration: 44000 nM
Estimate against measurement, compound 3: 1.3-fold (0.10 log units) below, within the range that was stated.
By their numbers in this assay, from the lowest: compounds 2, 1 and 3 (each within the scatter of the next).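

Moving the methyl group around the phenyl ring on the saturated ring carbon, with the atoms otherwise unchanged, gives a 1.3-fold higher number from compound 2 to compound 3 (0.10 log units; within the scatter) in this assay, so 3-methylphenyl and 4-methylphenyl cannot be told apart on this read-out. Replacing 2-fluorophenyl with 3-methylphenyl gives a 1.1-fold higher number from compound 1 to compound 3 (0.05 log units; within the scatter), so the three phenyl groups at this position remain indistinguishable, now including a change in where the methyl group sits as well as a change of group. Nothing measured here offers an explanation for how close these compounds lie.

As far as these compounds go, all three groups at this position are phenyl rings, so the effect of a different kind of group there, such as an amine, a carboxylic acid or a longer alkyl chain, remains open. From the compounds shown here alone, whether replacing the 4-sulfamoylphenyl group would shift the number is also open.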